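This account rests on a few compounds, and the source may have more. Where it says the series, first, only, none or still open, it means among the compounds named here.

Compound 1 `COc1cc(/C=C/C(=O)c2ccccc2[N+](=O)[O-])cc(OC)c1` and compound 2 `COc1cc(/C=C/C(=O)c2ccccc2F)cc(OC)c1` share one core, while compound 3 `COc1ccc(C(=O)/C=C/c2cccc([N+](=O)[O-])c2)c(OC)c1OC` and compound 4 `COc1ccc(C(=O)/C=C/c2cccc(F)c2)c(OC)c1OC` share another; the difference between the two cores is not broken down here. In a functional assay (Homo sapiens) for inhibition (a higher number here means a weaker inhibitor, a lower number a stronger inhibitor), compound 1 gives 3700 nM, and compound 2 gives 6000 nM. The change between them, (fluoro in place of nitro on an aromatic carbon), produced a step of a 1.6-fold higher number from compound 1 to compound 2 (0.21 log units; within the scatter). In this assay compound 3 gives 36000 nM, the highest of the three numbers. Compound 4 carries the same kind of change, (fluoro in place of nitro on an aromatic carbon), though here the fluoro sits meta to a large group rather than ortho to it. Because the step of a 1.6-fold higher number from compound 1 to compound 2 (0.21 log units; within the scatter) stayed within the scatter, the expected step is a 1.4-fold higher number from compound 3 to compound 4 (0.14 log units; within the scatter). Compound 4 is therefore estimated at 50000 nM, with a likely range from 15000 nM to 150000 nM.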

Compound 4, half-maximal inhibitory concentration: 6400 nM
For compound 4 the middle estimate is 7.8-fold (0.89 log units) above the measured one; the measured number lies below the stated range.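

Fluoro in place of nitro gave a 5.6-fold lower number from compound 3 to compound 4 (0.75 log units; beyond the scatter) in this assay and so did not carry over with the same size from the core of compound 1 to the core of compound 3: the same change on two cores in this assay, a 1.6-fold higher number (0.21 log units; within the scatter) from compound 1 to compound 2 and a 5.6-fold lower number (0.75 log units; beyond the scatter) from compound 3 to compound 4, 9.1-fold (0.96 log units) apart, beyond the scatter of two such steps. In these two pairs, then, the step measured on one core was a poor guide to the step on the other. The pairs do not show what sets the steps apart, since the cores differ and the fluoro also stands at a different place, and two pairs support no general rule for the series.

Going by these compounds, what remains open is whether an amine, a carboxylic acid or a nitrile in place of nitro would also give different steps on the two cores. On these data alone, it is also open whether fluoro and nitro would give a similar gap at other places on these rings.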